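Replacing fluoro with hydroxy on a fast-cleared compound

A few compounds are considered here, and "the series" means these few. Any claim that something is new, unique, unknown or untested is made for them only; others in the source may bear on it.

Measured in an ADME assay (liver) for metabolic stability, with Liver microsome (Rattus norvegicus) as the target, using microsomes; on this read-out higher numbers stand for fast clearance and lower numbers for slow clearance:
- compound 1 `O=C(O)c1csc(-n2nc(-c3ccccc3)c3ccncc32)n1`: 69 mL/min/kg
- compound 2 `O=C(O)c1csc(-n2nc(-c3ccccc3)c3ccc(F)cc32)n1`: 337 mL/min/kg

Compound 2 has the higher of the two numbers, and its gap to compound 1 lies beyond the usual scatter. Compound 3 `O=C(O)c1csc(-n2nc(-c3ccccc3)c3ccc(O)cc32)n1` is still unmeasured and carries hydroxy in place of fluoro on an aromatic carbon. Among the measured compounds shown here, no measured pair isolates this swap, so the expectation is loose: a moderate fall in this assay, which would still leave compound 3 short of the low number held by compound 1. The expected change is a 2.0-fold lower number from compound 2 to compound 3 (0.30 log units; within the scatter). For compound 3 the estimate is 170 mL/min/kg, with a range of 60 mL/min/kg to 420 mL/min/kg.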

Compound 3, clearance: 522 mL/min/kg
Compound 3: the middle estimate sits 3.1-fold (0.49 log units) below what was measured; the measured number lies above the stated range.
By their numbers in this assay, from the lowest: compound 1; then compounds 2 and 3 (each within the scatter of the next).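

In this assay, putting hydroxy in place of fluoro on this aromatic carbon gives a 1.5-fold higher number from compound 2 to compound 3 (0.19 log units; within the scatter), so the swap cannot be told apart from repeat-measurement noise. At this position, then, gaining a hydrogen-bond donor and acceptor leaves compound 3 reading much like compound 2. Nothing available here explains this result.
Still open, as far as these compounds go, is whether a methoxy group or an amine on the same carbon would shift the clearance beyond the scatter. From the compounds shown here alone, it is also open whether a hydrogen atom there would read any differently from fluoro or hydroxy.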